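The source may report more compounds than this note shows. Statements on the series, on what has been measured and on what is new or still open speak of the compounds shown alone.

Measured compounds in a functional assay on HEp-2 cells (Homo sapiens) for cytotoxicity, read by sulforhodamine B assay, with a stated time of 48 h; on this read-out lower numbers stand for stronger inhibition and higher numbers for weaker inhibition:

Compound 1 `COc1ccc(C2CC(c3ccco3)=NN2C(C)=O)cc1` gives 15600 nM.
Compound 2 `COc1ccc(C2CC(c3ccco3)=NN2C(C)=O)cc1OC` gives 9990 nM.
Compound 3 `COc1ccc(C2CC(c3ccc4ccccc4c3)=NN2CC=O)c(OC)c1OC` gives 590 nM.

Compound 3 stands lowest of the three, and its gap to compound 2 and to compound 1 is in each case beyond the scatter. How the core of compound 3 differs from the core of compound 2 is not broken down here; the two differ in more than one place.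

One structural change recurs in the series. From compound 2 to compound 1 it is hydrogen in place of methoxy on an aromatic carbon, and in this assay it gave a 1.6-fold higher number from compound 2 to compound 1 (0.19 log units; within the scatter). The same kind of change is proposed for compound 4 `COc1ccc(C2CC(c3ccc4ccccc4c3)=NN2CC=O)cc1OC`, not yet measured, as hydrogen in place of methoxy on an aromatic carbon. The surroundings are not identical: in the measured pair the leaving methoxy sits ortho to a methoxy group and meta to a large group, whereas in compound 3 it sits ortho to a large group, ortho to a methoxy group and meta to a methoxy group. So this is the same kind of change, not the same change.

Expectation for compound 4 in this assay rests on the measured step, where compound 2 to compound 1 gave a 1.6-fold higher number from compound 2 to compound 1 (0.19 log units; within the scatter), a step within the scatter. Among the compounds with values here, with only one prior instance, and in a different setting, the expected step is a 1.9-fold higher number from compound 3 to compound 4 (0.27 log units; within the scatter), with wide uncertainty. Compound 4 is estimated at 1100 nM, within 400 nM to 3500 nM.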

Compound 4, half-maximal inhibitory concentration: 1010 nM
Beside the measured number, compound 4's estimate is 1.1-fold (0.04 log units) above it; the range from low to high includes it.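

In this assay, hydrogen in place of methoxy on an aromatic carbon gives a 1.7-fold higher number from compound 3 to compound 4 (0.23 log units; within the scatter), and the step reads alike on the two cores: the same change on two cores in this assay, a 1.6-fold higher number (0.19 log units; within the scatter) from compound 2 to compound 1 and a 1.7-fold higher number (0.23 log units; within the scatter) from compound 3 to compound 4, 1.1-fold (0.04 log units) apart, within the scatter of two such steps. Within the data shown here, the change therefore carries from the core of compound 2 to the core of compound 3 without a step beyond the scatter, even though the leaving methoxy in compound 3 sits ortho to a large group, ortho to a methoxy group and meta to a methoxy group, unlike the one in compound 2. Among these compounds, this does not show that the step would hold on any other core or at any other place on the ring, and with both steps within the scatter and only two pairs to compare, it cannot show that the methoxy contributes anything to the read-out or that it contributes nothing.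

The compounds shown leave open what happens when a group other than hydrogen takes the place of this methoxy, for example a hydroxyl, an amine or a carboxylic acid. Among the compounds shown here, they also leave open which of the several differences between the core of compound 2 and the core of compound 3 goes with the lower numbers of compound 3 and compound 4, as no pair here separates them.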